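The source may hold more compounds than are shown below. What is called first, only, known or untested is meant among the compounds shown, and "the series" means these compounds.

Compound 1, `CCc1ccc(S(=O)(=O)NC(=O)Nc2ccc(Cl)cc2)s1`, gives 89% in a functional assay on the whole organism (6C3HED cells, Mus musculus) for inhibition, at a dose of 300 mg/kg by the oral route; a lower number here means less inhibition, a higher number more inhibition at the dose given (going by the name of the read-out).
Compound 2, `Cc1ccsc1S(=O)(=O)NC(=O)Nc1ccc(Cl)cc1`, gives 62% in this assay.

Compound 2 stands lowest of the two numbers in this assay; its nearest neighbour is compound 1, and the step of a number 27 percentage points lower from compound 1 to compound 2 (beyond the scatter) lies beyond the scatter. Compound 3, `CCc1csc(S(=O)(=O)NC(=O)Nc2ccc(Cl)cc2)c1`, has not yet been measured in this assay. It differs from compound 2 in one place: a group of 7 heavy atoms (6 carbon, 1 sulfur; one five-membered aromatic ring with 1 hetero atom) in place of a group of 6 heavy atoms (5 carbon, 1 sulfur; one five-membered aromatic ring with 1 hetero atom), on a sulfonyl sulfur. Among the measured compounds shown here, the only measured step that bears on this change is a number 27 percentage points lower from compound 1 to compound 2 (beyond the scatter), where exchanging one thiophene-based group for another on the sulfonyl sulfur shifted the inhibition by a modest amount. Compound 3 carries a larger ring group, as compound 1 does, rather than the 3-methylthiophen-2-yl of compound 2, so a reading between compound 2 and compound 1 seems plausible. A modest rise, a number 13 percentage points higher from compound 2 to compound 3 (beyond the scatter), is expected in this assay for compound 3. Compound 3 is estimated at 75%, within 50% to 95%.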

Compound 3, a percentage reported as inhibition, in the whole organism at one dose (the size of the read-out at that dose, not a potency): 93%
Compound 3: middle estimate off by 18 percentage points, on the low side; measured number inside the range.
By their numbers in this assay, from the lowest: compound 2; then compounds 1 and 3 (each within the scatter of the next).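

Replacing 3-methylthiophen-2-yl on the sulfonyl sulfur with the group of 7 heavy atoms gives a large change in this assay, with a number 31 percentage points higher from compound 2 to compound 3 (beyond the scatter). The two groups of 7 heavy atoms, 5-ethylthiophen-2-yl and the group in compound 3, cannot be told apart at this position, given a number 4 percentage points higher from compound 1 to compound 3 (within the scatter); among these three compounds, therefore, only compound 2 stands apart, and none goes against that reading. Nothing measured here accounts for the difference.

The compounds shown leave open whether the lower number of compound 2 follows from the count of heavy atoms or from how the group is arranged on its ring. They also leave open how a longer chain such as propyl, an amine or a carboxylic acid on the thiophene ring would read in this assay.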